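Chalcones with an ether side chain against HCT-15 growth

The compounds below may be only part of what the source reports. "The series", "measured", "known", "first", "only" and "open" are said of these compounds alone.

Compound 1 `COc1cccc(OCCC(C)(C)C)c1C(=O)/C=C/c1ccc(O)cc1`: > 30000 nM
Compound 2 `O=C(/C=C/c1ccc(O)cc1)c1c(O)cccc1OCCC1CCCC1`: 3310 nM
Compound 3 `CC(C)(C)CCOc1cccc(O)c1C(=O)CCc1ccc(O)cc1`: > 30000 nM

The three measured compounds were tested in a functional assay on HCT-15 cells (Homo sapiens) for antiproliferative activity, read by sulforhodamine B assay; a lower number here means a stronger inhibitor of growth, a higher number a weaker inhibitor of growth. Compound 1 gives > 30000 nM, which is a limit of the assay and not a number. Compound 3 likewise gives > 30000 nM, again a limit. Compound 2 is therefore the only one of the three with a proper number, 3310 nM, and so it stands alone among the values shown; the other two sit at the limit of > 30000 nM in this assay, at which 2 of the 3 values shown sit.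

Compound 4 `CC(C)(C)CCOc1cccc(O)c1C(=O)/C=C/c1ccc(O)cc1` has not yet been measured in this assay. It is obtained from compound 2 by a single change at the end of the side chain: tert-butyl in place of cyclopentyl on a saturated chain carbon, two bonds along the chain from an oxygen on an aromatic ring. The chain keeps its length and its link to the aromatic oxygen; only the cyclopentyl gives way to a tert-butyl, so that 2-cyclopentylethoxy becomes 3,3-dimethylbutoxy.

For the measured compounds named here, no measured pair shows what such a change does here, so no size of step can be read from the data. The writer expects a step from compound 2 to compound 4 of a 1.5-fold higher number from compound 2 to compound 4 (0.18 log units; within the scatter), small enough to lie within or near the scatter, with a lean toward weaker growth inhibition. Compound 4 is thus estimated at 5000 nM, within 1500 nM to 30000 nM.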

Compound 4, concentration for 50% growth inhibition: 3430 nM
For compound 4 the middle estimate is 1.5-fold (0.16 log units) above the measured one, within the range that was stated.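

In this assay, the change at the end of the side chain gives a 1.0-fold higher number from compound 2 to compound 4 (0.02 log units; within the scatter), so cyclopentyl and tert-butyl cannot be told apart at this position, and the ring of compound 2 is not needed for the growth inhibition seen with this chain length. For the compounds shown here, the result also gives the first reading of the oxygen on the aromatic ring, where hydrogen in place of methyl gives an at least 8.7-fold lower number from compound 1 to compound 4 (0.94 log units; beyond the scatter), so the free hydroxyl form is the one with a measurable value among this pair. That step can only be read as a lower bound, since compound 1 stands at a limit of the assay and not at a number: the limit of > 30000 nM in this assay, at which 2 of the 4 values shown sit.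

From the compounds shown here alone, whether an amine or a carboxylic acid at the end of the chain, or a longer chain or a shorter one, would keep the value of compound 4 remains open. Also open, going by these compounds, is how an ethyl group on that aromatic oxygen would compare with hydrogen and methyl, and whether methyl there would have the same effect with 2-cyclopentylethoxy as the side chain.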